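Changing the Group on the Sulfonyl Sulfur

This account rests on a few compounds, and the source may have more. Where it says the series, first, only, none or still open, it means among the compounds named here.

The three measured compounds were assessed in a functional assay on CHO cells for antagonist activity at 5-hydroxytryptamine receptor 6 (Homo sapiens), read by FLIPR; on this read-out lower numbers stand for stronger inhibition and higher numbers for weaker inhibition. Compound 1 `COc1ccc(S(=O)(=O)N2CC(C(=O)NC3CCN(C)CC3)c3ccccc32)c2ccccc12` gives 25.1 nM in this assay. Compound 2 `COc1ccc(S(=O)(=O)N2CC(C(=O)NC3CCN(Cc4ccccc4)CC3)c3ccccc32)c2ccccc12` carries phenyl in place of hydrogen on a saturated chain carbon bound to an amine nitrogen in a ring, and in this assay compound 2 gives 50.1 nM; the step of a 2.0-fold higher number from compound 1 to compound 2 (0.30 log units; within the scatter) stays within the scatter. Compound 3 `CN1CCC(N(C)C(=O)C2CN(S(=O)(=O)C3=CC4CCOC4C=C3)c3ccccc32)CC1` gives 31.6 nM in this assay, the second highest of the three numbers, though its gap to compound 1 and its gap to compound 2 both lie within the scatter.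

Compound 4 `CN1CCC(N(C)C(=O)C2CN(S(=O)(=O)c3ccc(OC(F)(F)F)cc3)c3ccccc32)CC1` has not yet been measured. It differs from compound 3 in a single place: a group of 11 heavy atoms (7 carbon, 1 oxygen, 3 fluorine; one six-membered aromatic ring of carbon only) in place of a group of 9 heavy atoms (8 carbon, 1 oxygen; one five-membered non-aromatic ring with 1 hetero atom, one six-membered non-aromatic ring of carbon only), on a sulfonyl sulfur. For the measured compounds named here, no measured step bears on this change. Going by the values given here, the only step among the measured compounds, from compound 1 to compound 2, concerns the amine nitrogen in the ring, while compound 1 and compound 3 differ in more than one place, so no single step can be read from them.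

In the absence of a relevant step, compound 4 is expected to stay close to compound 3, with an estimated step of a 1.3-fold higher number from compound 3 to compound 4 (0.10 log units; within the scatter) that lies within the scatter. The estimate for compound 4 in this assay is 40 nM, with a range from 10 nM to 160 nM.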

Compound 4, inhibition constant: 20 nM
For compound 4 the middle estimate is 2.0-fold (0.30 log units) above the measured one, within the range that was stated.
By their numbers in this assay, from the lowest: compounds 4, 1, 3 and 2 (each within the scatter of the next, the first and the last beyond it).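

The exchange on the sulfonyl sulfur, read in this assay, gives a 1.6-fold lower number from compound 3 to compound 4 (0.20 log units; within the scatter) and is the first step shown at this position, since the earlier step concerned only the amine nitrogen in the ring. With the sulfonamide nitrogen in the ring as its other neighbour, the sulfonyl sulfur can therefore carry either 4-(trifluoromethoxy)phenyl, with its six-membered aromatic ring of carbon only, or the group of compound 3, with its five-membered and six-membered non-aromatic rings, without a shift beyond the scatter, even though the two groups differ in their ring types and heavy-atom counts. No available measurement accounts for this result or ties it to any feature of either group.

This single step cannot separate the contribution of the aromatic ring from that of the trifluoromethoxy group it carries, so an unsubstituted phenyl would be needed to tell them apart. It also leaves open how far this tolerance extends, for instance to a pyridine ring or to a phenyl ring bearing a carboxylic acid or an amine on the sulfonyl sulfur.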